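Swapping One Benzyl Group in a Small Antiproliferative Series

The source may report more compounds than this note shows. Statements on the series, on what has been measured and on what is new or still open speak of the compounds shown alone.

Compound 1 `Fc1ccc(CSc2nnc(-c3cnccn3)s2)c(F)c1`: 20900 nM
Compound 2 `Brc1cccc(CSc2nnc(-c3cnccn3)n2-c2ccccc2)c1`: 9580 nM

Both compounds were tested in a functional assay on HeLa cells (Homo sapiens) for antiproliferative activity, read by MTT assay, with a stated time of 48 h; a higher number here means a weaker inhibitor, a lower number a stronger inhibitor. Compound 2 holds the lower of the two numbers, 9580 nM, which makes it the stronger inhibitor of the pair. Compound 1 gives 20900 nM, and this gap lies beyond the usual scatter of repeated measurements.

The next compound, compound 3 `Fc1cccc(F)c1CSc1nnc(-c2cnccn2)n1-c1ccccc1`, keeps everything in compound 2 except one group: 2,6-difluorophenyl in place of 3-bromophenyl on a saturated chain carbon bound to a sulfur. Cut one bond further out, the same change reads 3-bromobenzyl to 2,6-difluorobenzyl.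

Among the compounds with values here, no two measured compounds differ only at this place, so the data contain no direct measure of such a swap. Compound 1 also carries fluorine on this ring and gives 20900 nM, but it differs from compound 2 elsewhere too, which makes it a weak guide. A small move towards a higher number is expected, perhaps none beyond the scatter. The expected change is a 1.3-fold higher number from compound 2 to compound 3 (0.10 log units; within the scatter). For compound 3 the estimated value is 12000 nM, with an expected range from 5000 nM to 30000 nM.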

Compound 3, half-maximal inhibitory concentration: > 50000 nM
Compound 3: a limit, no number (the forecaster's own chance of this, stated with the estimate: 8%); middle value at least 4.1-fold (0.61 log units) from the limit.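

This step gives the first direct measure at this position: with the rest of the molecule unchanged, 2,6-difluorophenyl in place of 3-bromophenyl on a saturated chain carbon bound to a sulfur gives an at least 5.2-fold higher number from compound 2 to compound 3 (0.71 log units; beyond the scatter) in this assay. The group on this carbon therefore matters for the read-out, since exchanging one benzyl group for another, with no change in the count of hydrogen-bond donors, hydrogen-bond acceptors or net charge, moves the result beyond the scatter. Compound 3 is read only as a limit, so the step has a lower bound but no measured size: the limit of > 50000 nM in this assay, at which 1 of the 3 values shown sits.

This single swap removes the bromine and brings in two fluorines at once, so the compounds shown cannot separate the effect of the kind of halogen from that of its place on the ring. They also leave open how this position would respond to a different kind of group, such as a benzyl carrying an amine or a methoxy group, or a longer chain in place of the benzyl.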